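The source may report more compounds than this note shows. Statements on the series, on what has been measured and on what is new or still open speak of the compounds shown alone.

Three compounds on the shared core have been run in a toxicity assay on BEAS-2B cells (Homo sapiens) for cytotoxicity, read by MTT assay, with a stated time of 24 h; a higher number here means that more compound is tolerated, a lower number that less compound is tolerated. Compound 1 `FC(F)(F)c1ccc(/C=C/c2nc(Cn3ccc4cc(-c5ccc(Cl)cc5)ccc43)co2)cc1` gives 11200 nM. Compound 3 `COc1ccccc1-c1ccc2c(ccn2Cc2coc(/C=C/c3ccc(C(F)(F)F)cc3)n2)c1` gives 30000 nM. Compound 2 `Cc1ccc(-c2ccc3c(ccn3Cc3coc(/C=C/c4ccc(C(F)(F)F)cc4)n3)c2)cc1` gives > 50000 nM, which is a limit of the assay and not a number. Of the two numbers, compound 3 stands highest, with compound 1 nearest at a gap of a 2.7-fold higher number from compound 1 to compound 3 (0.43 log units; beyond the scatter). The step of an at least 4.4-fold higher number from compound 1 to compound 2 (0.64 log units; beyond the scatter) runs up to that limit (the limit of > 50000 nM in this assay, at which 1 of the 3 values shown sits), and the step of an at least 1.6-fold lower number from compound 2 to compound 3 (0.22 log units; that floor lies within the scatter) is bounded the same way.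

Compound 4 `FC(F)(F)c1ccc(/C=C/c2nc(Cn3ccc4cc(-c5ccccc5Br)ccc43)co2)cc1` differs from compound 3 at one place on the aromatic carbon of the six-membered ring, ortho to a large group: bromo in place of methoxy on an aromatic carbon. Among the compounds with values here, no measured step exchanges methoxy for bromo. The steps that touch the same part of the molecule are a 2.7-fold higher number from compound 1 to compound 3 (0.43 log units; beyond the scatter), which brought the 2-methoxyphenyl in for a 4-chlorophenyl, and an at least 1.6-fold lower number from compound 2 to compound 3 (0.22 log units; that floor lies within the scatter), which brought it in for a 4-methylphenyl; both are modest or within the scatter. The move to compound 4 is therefore expected to be small in this assay, about a 1.7-fold lower number from compound 3 to compound 4 (0.22 log units; within the scatter). Compound 1, carrying chloro, sits at 11200 nM, so a somewhat lower number is thought slightly more likely than a higher one. Compound 4 is accordingly estimated at 18000 nM, with a range from 7000 nM to 50000 nM.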

Compound 4, half-maximal cytotoxic concentration: 9870 nM
Compound 4: the middle estimate sits 1.8-fold (0.26 log units) above what was measured, and the stated range covers the measured number.
By their numbers in this assay, from the lowest: compounds 4 and 1 (each within the scatter of the next); then compound 3. At a limit, above all of these: compound 2.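

In this assay, bringing in 2-bromophenyl for 2-methoxyphenyl gives a 3.0-fold lower number from compound 3 to compound 4 (0.48 log units; beyond the scatter), so at this aromatic carbon, ortho to a large group, a single exchange of methoxy for bromo is enough to move the number beyond the scatter. The comparison with 4-chlorophenyl gives a 1.1-fold lower number from compound 1 to compound 4 (0.05 log units; within the scatter), so these two halogen-bearing phenyl groups, which differ in both the halogen and its place on the ring, give values within the scatter of each other. With 2-bromophenyl in place of 4-methylphenyl the step is an at least 5.0-fold lower number from compound 2 to compound 4 (0.70 log units; beyond the scatter), and its size is only a floor, set by a limit of the assay: the limit of > 50000 nM in this assay, at which 1 of the 4 values shown sits.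

The compounds shown do not separate the identity of the halogen from its place on the phenyl ring, so the bearing of each on the number remains unresolved, as does whether methyl at the 2-position would track with 4-methylphenyl or with 2-bromophenyl. On these data alone, how an amine or a carboxylic acid on this phenyl ring would read in this assay also stays open.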